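This account rests on a few compounds, and the source may have more. Where it says the series, first, only, none or still open, it means among the compounds named here.

Compound 1 `NS(=O)(=O)c1ccc(N2N=C(c3ccc(OCc4ccccc4)cc3)CC2c2ccc(Cl)cc2)cc1`: 82000 nM
Compound 2 `NS(=O)(=O)c1ccc(N2N=C(c3ccc(OCc4ccccc4)cc3)CC2c2ccccc2F)cc1`: > 100000 nM, a limit of the assay
Compound 3 `NS(=O)(=O)c1ccc(N2N=C(c3ccc(OCc4ccccc4)cc3)CC2c2cccc(Cl)c2)cc1`: 85000 nM
Compound 4 `NS(=O)(=O)c1ccc(N2N=C(c3ccc(OCc4ccccc4)cc3)CC2c2cccc(F)c2)cc1`: not yet measured

In an ADME assay on Vero 76 cells (Chlorocebus sabaeus) for cytotoxicity, read by MTT assay, with a stated time of 96 h (on this read-out lower numbers stand for higher toxicity in this test and higher numbers for lower toxicity in this test), compound 3 gives 85000 nM. Among the compounds with values here, the only exact number to compare it with is that of compound 1, and the two lie within the scatter of each other. For compound 2 the value > 100000 nM is a limit and not a number.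

The next step leads to compound 4, which carries fluoro in place of chloro on an aromatic carbon, turning 3-chlorophenyl into 3-fluorophenyl: fluoro in place of chloro on an aromatic carbon. Within the data shown here, no measured pair isolates this swap at one place, so the evidence is indirect. Exchanging 4-chlorophenyl for 3-chlorophenyl gives a 1.0-fold higher number from compound 1 to compound 3 (0.02 log units; within the scatter). Exchanging 4-chlorophenyl for 2-fluorophenyl gives an at least 1.2-fold higher number from compound 1 to compound 2 (0.08 log units; that floor lies within the scatter), and exchanging 2-fluorophenyl for 3-chlorophenyl gives an at least 1.1-fold lower number from compound 2 to compound 3 (0.07 log units; that floor lies within the scatter). None of these steps shows a change beyond the scatter in this assay, so no clear shift in either direction is expected here. The expected change is a 1.1-fold higher number from compound 3 to compound 4 (0.02 log units; within the scatter). For compound 4 the estimated value is 90000 nM, with an expected range from 50000 nM to 100000 nM.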

Compound 4, half-maximal cytotoxic concentration: 90000 nM
For compound 4 middle estimate and measured number coincide at the digits printed; measured number inside the range.
By their numbers in this assay, from the lowest: compounds 1, 3 and 4 (each within the scatter of the next). At a limit, above all of these: compound 2.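

In this assay, the exchange of chloro for fluoro on an aromatic carbon, meta to a large group, now stands alone at one place, and it gives a 1.1-fold higher number from compound 3 to compound 4 (0.02 log units; within the scatter). Set against the other two aryl groups, the 3-fluorophenyl group gives a 1.1-fold higher number from compound 1 to compound 4 (0.04 log units; within the scatter) and an at least 1.1-fold lower number from compound 2 to compound 4 (0.04 log units; that floor lies within the scatter), so neither the change of halogen at this position nor these changes of aryl group move the read-out beyond the scatter. For compound 2 the value > 100000 nM is a limit and not a number, so the step to compound 4 gives only a floor: the limit of > 100000 nM in this assay, at which 1 of the 4 values shown sits.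

The compounds shown carry only chloro or fluoro on this ring, and they leave open whether a group of another kind at this place, such as an amine, a carboxylic acid or a methoxy group, would give a step beyond the scatter in this assay. They also do not tell whether a change elsewhere on the shared core would shift the number more than these exchanges on the aryl ring do.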